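The source may hold more compounds than are shown below. What is called first, only, known or untested is meant among the compounds shown, and "the series" means these compounds.

Of the compounds shown here, three sharing one core have been measured in a functional assay on SW-620 cells (Homo sapiens) for cytotoxicity, read by MTT assay, with a stated time of 72 h (on this read-out lower numbers stand for stronger inhibition and higher numbers for weaker inhibition), and they differ only in the group on a double-bonded chain carbon bound to a double-bonded ring carbon. Compound 1 (`COc1cccc(/C=C2\CCC/C(=C\c3ccc(Cl)cc3)C2=O)c1OC`) gives 11100 nM, compound 2 (`COc1cccc(/C=C2\CCC/C(=C\c3cccc(O)c3)C2=O)c1OC`) gives 6400 nM, and compound 3 (`COc1cccc(/C=C2\CCC/C(=C\c3cc(Cl)cc(Cl)c3)C2=O)c1OC`) gives 5500 nM. Compound 3 therefore cannot be separated from the other two: the measurements show a 2.0-fold lower number from compound 1 to compound 3 (0.30 log units; within the scatter) and a 1.2-fold lower number from compound 2 to compound 3 (0.07 log units; within the scatter). The remaining pair behaves the same way, with a 1.7-fold lower number from compound 1 to compound 2 (0.24 log units; within the scatter).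

The next structure is compound 4 (`COc1cccc(/C=C2\CCC/C(=C\c3ccc(O)c(O)c3)C2=O)c1OC`), reached from compound 3 by one change: 3,4-dihydroxyphenyl in place of 3,5-dichlorophenyl on a double-bonded chain carbon bound to a double-bonded ring carbon. Here 3,4-dihydroxyphenyl stands in place of 3,5-dichlorophenyl. For the measured compounds named here, no measured step covers this exact exchange. The closest evidence is compound 2, which also carries a hydroxyl-bearing phenyl group, and the measured exchange with 3,5-dichlorophenyl gave a 1.2-fold lower number from compound 2 to compound 3 (0.07 log units; within the scatter). Since every measured step at this place stays within the scatter, no step beyond the scatter is expected in this assay, and no firm direction can be drawn from these data. The expected change is a 1.2-fold lower number from compound 3 to compound 4 (0.09 log units; within the scatter). Compound 4 is estimated at 4500 nM, with an expected range from 1500 nM to 11000 nM.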

Compound 4, half-maximal inhibitory concentration: 6300 nM
Beside the measured number, compound 4's estimate is 1.4-fold (0.15 log units) below it, within the range that was stated.
By their numbers in this assay, from the lowest: compounds 3, 4, 2 and 1 (each within the scatter of the next).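

Exchanging 3,5-dichlorophenyl, which has no hydrogen-bond donors or acceptors, for 3,4-dihydroxyphenyl, which has both, still leaves this assay within the scatter, with a 1.1-fold higher number from compound 3 to compound 4 (0.06 log units; within the scatter) on a double-bonded chain carbon bound to a double-bonded ring carbon. The new compound also allows a single-site reading of hydroxy in place of hydrogen on an aromatic carbon, which gives a 1.0-fold lower number from compound 2 to compound 4 (0.01 log units; within the scatter), while the exchange with 4-chlorophenyl gives a 1.8-fold lower number from compound 1 to compound 4 (0.25 log units; within the scatter), so chlorinated and hydroxylated phenyl groups at this place cannot be told apart among these four compounds. No independent information bears on why the numbers at this position stay so close.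

The compounds shown leave open whether a group of another kind at this place, such as an amine, a carboxylic acid or a longer chain in place of the substituted phenyl ring, would give a step beyond the scatter. They also leave open whether changes elsewhere on the shared core would separate these compounds.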